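A few compounds are considered here, and "the series" means these few. Any claim that something is new, unique, unknown or untested is made for them only; others in the source may bear on it.

Two cores are in play. Compound 1 `COc1ccc(/C=C/C(=O)C(=Cc2ccc(O)c(F)c2)C(=O)/C=C/c2ccc(OC)cc2OC)c(OC)c1` and compound 2 `COc1ccc(/C=C/C(=O)C(=Cc2cc(Br)c(O)c(OC)c2)C(=O)/C=C/c2ccc(OC)cc2OC)c(OC)c1` share one; compound 3 `COc1cc(OC)c(/C=C/C(=O)C(=Cc2ccc(O)c(F)c2)C(=O)/C=C/c2c(OC)cc(OC)cc2OC)c(OC)c1` and compound 4 `COc1cc(OC)c(/C=C/C(=O)C(=Cc2cc(Br)c(O)c(OC)c2)C(=O)/C=C/c2c(OC)cc(OC)cc2OC)c(OC)c1` share the other. The difference between the two cores is not broken down here.

In a functional assay on A549 cells (Homo sapiens) for antiproliferative activity, read by sulforhodamine B assay, with a stated time of 48 h (on this read-out higher numbers stand for weaker inhibition and lower numbers for stronger inhibition), compound 1 gives 2070 nM. In this assay compound 2 gives 1090 nM. The change between them is 3-bromo-4-hydroxy-5-methoxyphenyl in place of 3-fluoro-4-hydroxyphenyl on a double-bonded chain carbon bound to a double-bonded chain carbon, and it made a 1.9-fold lower number from compound 1 to compound 2 (0.28 log units; within the scatter). In this assay compound 3 gives 1060 nM; compound 3 and compound 2 lie within the scatter of each other, as do compound 3 and compound 1.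

Compound 4 carries the same change on the second core: 3-bromo-4-hydroxy-5-methoxyphenyl in place of 3-fluoro-4-hydroxyphenyl on a double-bonded chain carbon bound to a double-bonded chain carbon. Among the compounds with values here, the one earlier instance of this change lies within the scatter, so the only guide is a small shift toward a lower number, and the same kind of step is expected here. In this assay the expected step is a 1.8-fold lower number from compound 3 to compound 4 (0.25 log units; within the scatter), resting on a 1.9-fold lower number from compound 1 to compound 2 (0.28 log units; within the scatter). Compound 4 is estimated at 600 nM, with a range from 250 nM to 1500 nM.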

Compound 4, half-maximal inhibitory concentration: 730 nM
Compound 4: middle estimate off by 1.2-fold (0.09 log units), on the low side; the measured number falls inside the stated range.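

In this assay the change gives a 1.5-fold lower number from compound 3 to compound 4 (0.16 log units; within the scatter) on the second core, and set beside the step on the first core the two do not differ: the same change on two cores in this assay, a 1.9-fold lower number (0.28 log units; within the scatter) from compound 1 to compound 2 and a 1.5-fold lower number (0.16 log units; within the scatter) from compound 3 to compound 4, 1.3-fold (0.12 log units) apart, within the scatter of two such steps. As far as these two pairs go, 3-bromo-4-hydroxy-5-methoxyphenyl in place of 3-fluoro-4-hydroxyphenyl behaves alike on the core of compound 1 and the core of compound 3. Each step on its own lies within the scatter, however, so neither pair shows that the change really moves the number, and agreement between two such small steps says little about a third core.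

The bromine and the methoxy group enter together, which leaves open what each contributes alone. Also open, on these data alone, is what an amine or a carboxylic acid would do in place of the hydroxy group on this ring, on either core.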